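Adding a second fluorine to the aryl ring of compound 1

The source may report more compounds than this note shows. Statements on the series, on what has been measured and on what is new or still open speak of the compounds shown alone.

Compound 1 `O=C(N/N=C/c1ccccc1O)c1ccc(-c2ccc(F)cc2)o1`: 40%
Compound 2 `O=C(N/N=C/c1ccccc1Cl)c1ccc(-c2ccc(F)cc2)o1`: 4.81%
Compound 3 `O=C(N/N=C/c1ccc(O)cc1)c1ccc(-c2ccc(F)cc2)o1`: 10.6%

Of the compounds shown here, three sharing one core have been tested in a functional assay on Bel-7402 cells (Homo sapiens) for inhibition, read by sulforhodamine B assay, with a stated time of 48 h, tested at 10 uM; a lower number here means less inhibition of growth, a higher number more inhibition of growth at the concentration tested. Compound 1 stands highest of the three. Compound 2 differs from it by a chloro in place of the hydroxy on the aromatic carbon, and the step runs a number 35.2 percentage points lower from compound 1 to compound 2 (beyond the scatter). Compound 3 carries a 4-hydroxyphenyl in place of the 2-hydroxyphenyl, and here the step runs a number 29.4 percentage points lower from compound 1 to compound 3 (beyond the scatter). Between compound 2 and compound 3 the step is a number 5.8 percentage points higher from compound 2 to compound 3 (within the scatter). All of these changes sit on the ring attached to the carbon that is double-bonded to nitrogen.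

Compound 4 `O=C(N/N=C/c1ccccc1O)c1ccc(-c2ccc(F)cc2F)o1` changes the other side of the molecule: fluoro in place of hydrogen on an aromatic carbon, so that the 4-fluorophenyl becomes a 2,4-difluorophenyl. Among the compounds with values here, none of the measured steps touches this ring, so there is no measured step that bears on the change directly. With nothing to point up or down, the expectation for the step in this assay from compound 1 is no change at the digits printed from compound 1 to compound 4 (within the scatter), that is, no change beyond the scatter. Compound 4 is therefore estimated at 40%, with a range from 24% to 56%.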

Compound 4, percent growth inhibition at one concentration: 91.8%
The estimate for compound 4 lay 51.8 percentage points below the measured number; the measured number lies above the stated range.
By their numbers in this assay, from the lowest: compounds 2 and 3 (each within the scatter of the next); then compound 1; then compound 4.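

In this assay, the step of a number 51.8 percentage points higher from compound 1 to compound 4 (beyond the scatter) shows that the ring at the far end of compound 1 is not a silent part of the molecule: a single fluoro, ortho to a large group and meta to the existing fluoro group, turns the 4-fluorophenyl into a 2,4-difluorophenyl and changes the result strongly. Within the data shown here, the earlier steps from compound 1 all changed the other ring, and each of them lowered the number, so this is the first change here that raises it beyond the scatter, and it does so with just one added heavy atom. Nothing in the data shown explains why this one atom has such an effect.

As far as these compounds go, it remains open whether the rise belongs to fluoro itself or whether a methyl, a methoxy or an amine at the same place would do the same, and whether the fluoro at this place matters more than the fluoro group already on the ring. From the compounds shown here alone, it is also open whether the same change would lift compound 2 and compound 3, which lack the 2-hydroxyphenyl of compound 1.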